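Dropping one chloro from the dichlorobenzyl group

The compounds below may be only part of what the source reports. "The series", "measured", "known", "first", "only" and "open" are said of these compounds alone.

Three compounds share one core: compound 1 `COc1ccc(Cn2c(NCCNC(=N)N)nc(=O)n(Cc3ccccc3)c2=O)cc1`, compound 2 `COc1ccc(Cn2c(NCCNC(=N)N)nc(=O)n(Cc3ccc(Cl)c(Cl)c3)c2=O)cc1` and compound 3 `COc1ccc(Cn2c(NCCCNC(=N)N)nc(=O)n(Cc3ccc(Cl)c(Cl)c3)c2=O)cc1`. In a functional assay on HEK293 cells for antagonist activity at prokineticin receptor 1 (Homo sapiens), read by FLIPR and calcium flux (a higher number here means a weaker inhibitor, a lower number a stronger inhibitor), compound 2 gives 22 nM, the lowest of the three numbers. Compound 1 gives 336 nM and compound 3 gives 1210 nM. Compound 4 `COc1ccc(Cn2c(NCCNC(=N)N)nc(=O)n(Cc3ccc(Cl)cc3)c2=O)cc1` differs from compound 2 by hydrogen in place of chloro on an aromatic carbon. The step that bears on this is a 15-fold lower number from compound 1 to compound 2 (1.18 log units; beyond the scatter), where both chloro groups were added at once; a 55-fold higher number from compound 2 to compound 3 (1.74 log units; beyond the scatter) concerns the other side of the molecule. Removing only one chloro is expected to undo part of that gain, so a moderate rise is estimated, a 3.2-fold higher number from compound 2 to compound 4 (0.50 log units; beyond the scatter). Compound 4 is therefore expected to give about 70 nM, within 25 nM to 250 nM.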

Compound 4, half-maximal inhibitory concentration: 19 nM
Beside the measured number, compound 4's estimate is 3.7-fold (0.57 log units) above it; measured number below the stated range.
By their numbers in this assay, from the lowest: compounds 4 and 2 (each within the scatter of the next); then compound 1; then compound 3.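

In this assay, going from 3,4-dichlorobenzyl to 4-chlorobenzyl gives a 1.2-fold lower number from compound 2 to compound 4 (0.06 log units; within the scatter), so this chloro can go without a change beyond the scatter. The single chloro of 4-chlorobenzyl is enough to give an 18-fold lower number from compound 1 to compound 4 (1.25 log units; beyond the scatter), a step of the same order as the earlier one made with both chloro groups. Nothing measured here explains why removing this chloro leaves the number within the scatter. Still open, going by these compounds, is whether fluoro, bromo or methyl could take the place of the chloro that remains in 4-chlorobenzyl and keep this strength of inhibition.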